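The compounds below may be only part of what the source reports. "The series", "measured", "known", "first", "only" and "open" are said of these compounds alone.

Of the compounds shown here, three have been measured so far in an ADME assay on a cell-free system (plasma, Rattus norvegicus) for metabolic stability, read by LC-MS, with a stated time of 60 min, at 37 degrees C, tested at 50 uM; on this read-out higher numbers stand for a more stable compound and lower numbers for a less stable compound. Compound 1, `Cc1oc(=O)oc1COC(=O)N1C[C@@H]2C[C@H]1C(=O)Nc1cccc(c1)C(=O)OCc1oc(=O)oc1COC(=O)C1=C(S2)[C@H](C)[C@@H]2[C@@H]([C@@H](C)O)C(=O)N12`, gives 0%. Compound 2, `CCOC(=O)C1=C(S[C@H]2C[C@@H](C(=O)Nc3cccc(C(=O)OCC)c3)N(C(=O)OCc3oc(=O)oc3C)C2)[C@H](C)[C@@H]2[C@@H]([C@@H](C)O)C(=O)N12`, gives 0%. Compound 3, `CCOC(=O)C1=C(S[C@@H]2CN[C@H](C(=O)Nc3cccc(C(=O)OCC)c3)C2)[C@H](C)[C@@H]2[C@@H]([C@@H](C)O)C(=O)N12`, gives 0%. Compound 1 and compound 2 thus stand level at the digits read, and how their two cores differ is not broken down here.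

One structural change is seen twice. From compound 2 to compound 3 it is a hydrogen atom in place of a group of 11 heavy atoms (6 carbon, 5 oxygen; one five-membered aromatic ring with 2 hetero atoms), on an amine nitrogen in a ring, and it made the step of no change at the digits printed from compound 2 to compound 3 (within the scatter). The unmeasured compound 4, `C[C@@H](O)[C@H]1C(=O)N2C3=C(S[C@@H]4CN[C@@H](C4)C(=O)Nc4cccc(c4)C(=O)OCc4oc(=O)oc4COC3=O)[C@H](C)[C@H]12`, is reached from compound 1 by the same kind of change, (a hydrogen atom in place of a group of 11 heavy atoms (6 carbon, 5 oxygen; one five-membered aromatic ring with 2 hetero atoms), on an amine nitrogen in a ring); the surroundings differ in that the ring is part of a fused or bridged system of six rings and the neighbouring ring atom bears a fused ring rather than a large group.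

Because compound 1 gives 0% and the like change gave no change at the digits printed from compound 2 to compound 3 (within the scatter), the expected step is no change at the digits printed from compound 1 to compound 4 (within the scatter). Compound 4 is therefore estimated to give 0% in this assay, expected to lie between 0% and 10%.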

Compound 4, percent of the compound remaining: 0%
Beside the measured number, compound 4's estimate shows no gap at the digits printed; low and high end bracket the measured number.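

Leaving a hydrogen atom in place of the group of 11 heavy atoms on the amine nitrogen in the ring reads the same on both cores in this assay: the same change on two cores in this assay, no change at the digits printed (within the scatter) from compound 2 to compound 3 and no change at the digits printed (within the scatter) from compound 1 to compound 4, 0 percentage points apart, within the scatter of two such steps. The new step is no change at the digits printed from compound 1 to compound 4 (within the scatter), so on these two cores the change leaves the reading where it was, and compound 4 gives 0%. This does not show that the group has no bearing on stability: a compound with nothing left at the end of the assay cannot read any lower, so these readings cannot tell how quickly any of the four compounds disappears.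

Left open is whether a carboxylic acid in place of the ethyl ester groups of compound 3 would leave any compound remaining in this assay. Going by these compounds, on a core that gives a reading above zero, the same swap at the ring nitrogen could then be followed as a real difference, and whether it would move that reading remains unknown.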